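Tert-Butyl in Place of Methyl on a Core with Low Read-Out Numbers

This account rests on a few compounds, and the source may have more. Where it says the series, first, only, none or still open, it means among the compounds named here.

Three compounds share a single read-out in an assay on isolated protein for inhibition of MAP kinase-activated protein kinase 5 (Homo sapiens), read by mobility shift assay, tested at 30 uM; a higher number here means more inhibition at the concentration tested (going by the name of the read-out), a lower number less inhibition. Compound 1 `COCCNc1nc(C)cc2c1c(N)nn2C` gives 5% in this assay, and compound 2 `COCCNc1nc(-c2ccccc2)cc2c1c(N)nn2C` gives 1%. Compound 3 `Cc1cc2nn(-c3ccccc3)c(N)c2c(=O)[nH]1`, built on a different core, gives 5% in this assay. Compound 3 thus sits level with compound 1 at the digits shown and within the scatter of compound 2; none of the three numbers is separated from another by more than the usual scatter.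

The unmeasured compound 4 `CC(C)(C)c1cc2nn(-c3ccccc3)c(N)c2c(=O)[nH]1` differs from compound 3 in one place: tert-butyl in place of methyl on an aromatic carbon.

Among the compounds with values here, only one measured step bears on this change, and loosely. The replacement of an alkyl group by phenyl on an aromatic carbon, a number 4 percentage points lower from compound 1 to compound 2 (within the scatter), stayed within the scatter, on a core that already showed almost no inhibition. The present change, tert-butyl in place of methyl, is also an exchange of one carbon substituent for another on an aromatic carbon, and the starting number for compound 3 is equally low. Within the data shown here, no step in this set moved the read-out beyond the scatter, so no change beyond the scatter is expected for compound 4, that is a number 1 percentage points lower from compound 3 to compound 4 (within the scatter).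

Compound 4 is therefore estimated at 4% in this assay, with a range from -4% to 14%.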

Compound 4, a percentage reported as inhibition, at one concentration (the size of the read-out at that concentration, not a potency): 2%
The estimate for compound 4 lay 2 percentage points above the measured number; the measured number falls inside the stated range.
By their numbers in this assay, from the lowest: compounds 2, 4, 1 and 3 (each within the scatter of the next).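

On the core of compound 3, tert-butyl with its 4 heavy atoms on the aromatic carbon next to the ring nitrogen, in place of methyl with its 1 heavy atom, gives a number 3 percentage points lower from compound 3 to compound 4 (within the scatter) in this assay. Within the data shown here, this is the first reading at this place on this core, and it shows that a methyl there can give way to the much larger tert-butyl without the read-out leaving the scatter. Together with the exchange of methyl for phenyl on the core of compound 1, a number 4 percentage points lower from compound 1 to compound 2 (within the scatter), it makes two exchanges of a methyl for a larger carbon group on two cores, and neither goes beyond the scatter, though all these numbers lie close together and low, and nothing here accounts for the result.

As far as these compounds go, whether this aromatic carbon can carry anything that moves the read-out beyond the scatter remains open, for instance an amine, a carboxylic acid or a longer chain in place of the methyl of compound 3. Also open is how tert-butyl would read on the core of compound 1, where only methyl and phenyl are shown.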